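Methoxy groups in place of chlorine on the carbonyl ring

The source may report more compounds than this note shows. Statements on the series, on what has been measured and on what is new or still open speak of the compounds shown alone.

Measured so far:
compound 1, `COc1cc(-c2cc(/C=C/C(=O)c3ccc(Cl)c(Cl)c3)[nH]n2)cc(OC)c1OC`: 63300 nM
compound 2, `COc1ccc(-c2cc(/C=C/C(=O)c3cc(OC)c(OC)c(OC)c3)[nH]n2)cc1OC`: 3900 nM

Both compounds were tested in a functional assay on SF-268 cells (Homo sapiens) for inhibition, read by sulforhodamine B assay, with a stated time of 48 h; a lower number here means a stronger inhibitor of growth, a higher number a weaker inhibitor of growth. Compound 1 stands at the highest of the two numbers, and compound 2 lies well below it, beyond the usual scatter, although the two structures differ in more than one place, so no single change can be credited for that gap.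

Compound 3, `COc1ccc(C(=O)/C=C/c2cc(-c3cc(OC)c(OC)c(OC)c3)n[nH]2)cc1OC`, has not yet been measured. It differs from compound 1 in one place: 3,4-dimethoxyphenyl in place of 3,4-dichlorophenyl on a carbonyl carbon. Compound 3 is expected to give a lower number than compound 1, because compound 2, which likewise carries methoxy groups rather than chlorine on the ring at the carbonyl carbon, gives 3900 nM. The step of a 7.9-fold lower number from compound 1 to compound 3 (0.90 log units; beyond the scatter) is expected to be a fall beyond the scatter. Compound 3 is estimated at about 8000 nM, within a range of 2500 nM to 25000 nM.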

Compound 3, concentration for total growth inhibition: 3960 nM
Estimate against measurement, compound 3: 2.0-fold (0.31 log units) above; the measured number falls inside the stated range.
By their numbers in this assay, from the lowest: compounds 2 and 3 (each within the scatter of the next); then compound 1.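

In this assay, among the compounds shown here, the single change of 3,4-dimethoxyphenyl in place of 3,4-dichlorophenyl on a carbonyl carbon gives a 16-fold lower number from compound 1 to compound 3 (1.20 log units; beyond the scatter) and so makes a large step, beyond the scatter. This is the first pair shown that differs in one place only, so a gap that could not be credited to any single change before can now be tied to this position and this swap. No measurement shown speaks to why the number falls with this change.

From the compounds shown here alone, it remains open whether both methoxy groups are needed for the fall, or whether one methoxy group, or one chlorine, would give a similar number. Also open, going by these compounds, is how a hydroxyl group, an amine or a carboxylic acid on this ring would compare with 3,4-dimethoxyphenyl.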